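Shortening a Linker: From Compound 2 to Compound 3

A few compounds are considered here, and "the series" means these few. Any claim that something is new, unique, unknown or untested is made for them only; others in the source may bear on it.

Measured so far:
compound 1, `O=C(CI)NCCCCCCC(=O)NCCCCCCNc1ncnc2c1ncn2[C@@H]1O[C@H](COP(=O)(O)OP(=O)(O)OP(=O)(O)O)[C@@H](O)[C@H]1O`, gives 0%
compound 2, `O=C(CI)NCCC(=O)NCCCCCCNc1ncnc2c1ncn2[C@@H]1O[C@H](COP(=O)(O)OP(=O)(O)OP(=O)(O)O)[C@@H](O)[C@H]1O`, gives 0%

Both values come from an assay on isolated protein for inhibition of hexokinase-3 (Rattus norvegicus), with a stated time of 6 h, tested at 10 mM; a lower number here means less inhibition, a higher number more inhibition at the concentration tested (going by the name of the read-out). For the measured compounds named here, compound 2 stands level with compound 1, as the single measured step shows: no change at the digits printed from compound 1 to compound 2 (within the scatter). That step shortened the chain that carries the iodoacetamide group, and the read-out did not move.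

Compound 3, `O=C(CI)NCCCCCCCNc1ncnc2c1ncn2[C@@H]1O[C@H](COP(=O)(O)OP(=O)(O)OP(=O)(O)O)[C@@H](O)[C@H]1O`, takes the same kind of change one stage further. The difference from compound 2 is a group of 6 heavy atoms (3 carbon, 1 nitrogen, 1 oxygen, 1 iodine; no ring) in place of a group of 10 heavy atoms (5 carbon, 2 nitrogen, 2 oxygen, 1 iodine; no ring), on a saturated chain carbon, six bonds along the chain from a nitrogen on an aromatic ring. Going by the values given here, the only comparable step, from compound 1 to compound 2, was flat, and nothing else among the measured compounds suggests a different outcome for a shorter chain.

The step from compound 2 to compound 3 is therefore expected to show no change beyond the scatter: no change at the digits printed from compound 2 to compound 3 (within the scatter). For compound 3 the expected value in this assay is 0%, with a range from -8% to 10%.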

Compound 3, a percentage reported as inhibition, at one concentration (the size of the read-out at that concentration, not a potency): 20%
The estimate for compound 3 lay 20 percentage points below the measured number; the measured number lies above the stated range.
By their numbers in this assay, from the lowest: compounds 1 and 2 (each within the scatter of the next); then compound 3.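

In this assay, for the compounds shown here, this position turns out to respond to change: the switch to (((iodomethyl)carbonyl)amino)methyl gives a number 20 percentage points higher from compound 2 to compound 3 (beyond the scatter) and so lifts the read-out clear of the flat pair of earlier compounds, where the only step was no change at the digits printed from compound 1 to compound 2 (within the scatter). Unlike that earlier step, this one also changes the counts in the group, from 2 hydrogen-bond donors and 2 acceptors to 1 of each, so a shorter chain is not the only difference. No measurement here explains the rise.

The compounds shown cannot separate the effect of chain length from that of losing the inner amide, since both change in the same step. From the compounds shown here alone, it remains open whether a longer unbroken carbon chain with the same iodomethyl carbonyl end, or an amine at that end, would give a similar reading.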